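Replacing the ethoxy group with carboxymethyl on the shared core

The source may hold more compounds than are shown below. What is called first, only, known or untested is meant among the compounds shown, and "the series" means these compounds.

Measured so far:
Compound 1, `CCOc1ccc(N/N=C2\CCC(C)n3c2ncc(C(=O)O)c3=O)cc1`: 17600 nM
Compound 2, `CCOc1ccc(N/N=C2\CC[C@@H](C)n3c2ncc(C(=O)O)c3=O)cc1`: 1000 nM

Compound 1 has the highest of the two numbers in a functional assay (mast cells) for inhibition, with Rattus norvegicus as the target; a higher number here means that more compound is needed for the effect, a lower number that less compound is needed. Within the data shown here, its nearest neighbour is compound 2, reached by an 18-fold lower number from compound 1 to compound 2 (1.25 log units; beyond the scatter); the two compounds share every atom and bond, and the step is tied to the fact that one of compounds 1 and 2 is drawn with a defined configuration and the other without, at the place where they differ, since the only change is that a ring carbon is drawn with a defined configuration in compound 2 and without one in compound 1.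

Compound 3, `CC1CC/C(=N\Nc2ccc(CC(=O)O)cc2)c2ncc(C(=O)O)c(=O)n21`, has not yet been tested in this assay. It differs from compound 1 only in carboxymethyl in place of ethoxy on an aromatic carbon. Among the measured compounds shown here, no measured step touches that part of the molecule: the one step available concerns a stereocentre on the saturated ring, not the substituent on the aromatic ring. There is therefore no basis for expecting a shift in either direction beyond the scatter, and the estimate stays close to compound 1 with a wide range. Compound 3 is expected to give 20000 nM, between 4000 nM and 100000 nM, meaning a 1.1-fold higher number from compound 1 to compound 3 (0.06 log units; within the scatter).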

Compound 3, half-maximal effective concentration: 3400 nM
Compound 3: middle estimate off by 5.9-fold (0.77 log units), on the high side; the whole stated range lies above it.
By their numbers in this assay, from the lowest: compound 2; then compound 3; then compound 1.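

Among these compounds, until now, the only step on record lay at a ring carbon of the saturated ring, so nothing showed whether the group on the aromatic ring mattered. In this assay, carboxymethyl in place of ethoxy, on an aromatic carbon para to a large group, gives a 5.2-fold lower number from compound 1 to compound 3 (0.71 log units; beyond the scatter) and thereby shows that this position responds to a change of group, and that the carboxymethyl group is accepted there with less compound needed for the effect. Nothing available bears on why this step occurs, so it stands as an observation without a known cause.

The compounds shown leave open whether a carboxylic acid on a longer chain, or an amine, at this same place would lower the number further or raise it again, and which of the differences between carboxymethyl and ethoxy counts. They also leave open whether carboxymethyl would give a similar step on the R form drawn in compound 2, since compound 3 has that ring carbon drawn without a configuration.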